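A few compounds are considered here, and "the series" means these few. Any claim that something is new, unique, unknown or untested is made for them only; others in the source may bear on it.

For the measured compounds named here, in an ADME assay on the whole organism for inhibition, with Oryza sativa as the target, with a stated time of 4 days (on this read-out higher numbers stand for weaker inhibition and lower numbers for stronger inhibition), compound 1 `CCCN(CC)c1nc(Cl)nc(N[C@@H](C)c2ccccc2)n1` gives 479 nM, the lowest number of the three measured so far, against compound 2 `CNc1nc(Cl)nc(N[C@H](C)c2ccccc2)n1` at 22400 nM and compound 3 `CCCN(CC)c1nc(Cl)nc(N[C@H](C)c2ccccc2)n1` at 24500 nM. The large step of a 51-fold higher number from compound 1 to compound 3 (1.71 log units; beyond the scatter) goes with the fact that compounds 1 and 3 differ only in the configuration as drawn. Exchanging the amine among the compounds drawn R gives no step beyond the scatter: a 1.1-fold higher number from compound 2 to compound 3 (0.04 log units; within the scatter). Compound 4 `CCN(c1nc(Cl)nc(N[C@@H](C)c2ccccc2)n1)C(C)C` keeps the configuration of compound 1 and carries isopropyl in place of propyl on a nitrogen on an aromatic ring. Going by the values given here, only that one amine step bears on this change, so no step beyond the scatter is expected in this assay. The expected step is a 1.3-fold higher number from compound 1 to compound 4 (0.10 log units; within the scatter). For compound 4 the estimated value is 600 nM, with an expected range of 170 nM to 2200 nM.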

Compound 4, half-maximal inhibitory concentration: 537 nM
Beside the measured number, compound 4's estimate is 1.1-fold (0.05 log units) above it, and the stated range covers the measured number.
By their numbers in this assay, from the lowest: compounds 1 and 4 (each within the scatter of the next); then compounds 2 and 3 (each within the scatter of the next).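

In this assay, the exchange of propyl for isopropyl on a nitrogen on an aromatic ring gives a 1.1-fold higher number from compound 1 to compound 4 (0.05 log units; within the scatter). For the compounds shown here, earlier, a change of amine had been read only among compounds drawn R, and this step gives the first such reading with the configuration of compound 1. The only large step shown still goes with configuration: the fact that compounds 1 and 3 differ only in the configuration as drawn.

From the compounds shown here alone, it remains open whether a ring amine such as morpholine in place of ethyl(isopropyl)amino would stay within the scatter of compound 1. The same question stands for a longer chain such as hexyl on that nitrogen.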